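From phenyl to bromo in a cytotoxicity read-out

This account rests on a few compounds, and the source may have more. Where it says the series, first, only, none or still open, it means among the compounds named here.

Measured compounds:
compound 1 `CCCNC(=O)[C@@H]1C[C@H]2CCC[C@@H](C1)[C@@H]2NC(=O)c1cc2scnc2n1Cc1ccc(OC)cc1`: > 25000 nM
compound 2 `CCCNC(=O)[C@@H]1C[C@H]2CCC[C@@H](C1)[C@@H]2NC(=O)c1cc2sc(-c3ccccc3)nc2n1Cc1ccc(OC)cc1`: > 100000 nM
compound 3 `CCCNC(=O)[C@H]1[C@@H]2CCC[C@H]1CN(C(=O)c1cc3sc(-c4ccccc4)nc3n1Cc1ccc(OC)cc1)C2`: > 100000 nM

All three entries are limits, not numbers. In an ADME assay on HEK-293T cells (Homo sapiens) for cytotoxicity, read by luminescence and CellTiter-Glo, with a stated time of 24 h (a higher number here means that more compound is tolerated, a lower number that less compound is tolerated), compound 2 gives > 100000 nM, which is a limit. Compound 2 thus stands at the limit of > 100000 nM in this assay, at which 2 of the 3 values shown sit. Compound 1 stands at the limit of > 25000 nM in this assay, at which 1 of the 3 values shown sits.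

The next compound is compound 4 `CCCNC(=O)[C@@H]1C[C@H]2CCC[C@@H](C1)[C@@H]2NC(=O)c1cc2sc(Br)nc2n1Cc1ccc(OC)cc1`, with bromo in place of phenyl on an aromatic carbon. For the measured compounds named here, only one measured step bears on this carbon, with phenyl in place of hydrogen: a step that the two limits leave unreadable from compound 1 to compound 2. Its size cannot be read, so it gives no size or direction to carry over, and no step beyond the scatter is expected in this assay.

The expected change is an at least 1.2-fold lower number from compound 2 to compound 4 (0.09 log units; that floor lies within the scatter). Compound 4 is expected near 80000 nM. The estimated range for compound 4 runs from 25000 nM to 150000 nM.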

Compound 4, half-maximal cytotoxic concentration: > 100000 nM
Compound 4 was reported as a limit (the forecaster's own chance of this, stated with the estimate: 80%); middle value at least 1.2-fold (0.09 log units) from the limit.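

In this assay compound 4 gives > 100000 nM, which is a limit. No step can be read between compound 4 and either compound 1 or compound 2. The compounds shown leave open each one's actual half-maximal cytotoxic concentration, and whether hydrogen, phenyl or bromo on that aromatic carbon changes it.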